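The source may hold more compounds than are shown below. What is called first, only, known or untested is meant among the compounds shown, and "the series" means these compounds.

In a functional assay on SW480 cells (Homo sapiens) for antiproliferative activity, read by MTT assay, with a stated time of 48 h (on this read-out higher numbers stand for weaker inhibition and lower numbers for stronger inhibition), compound 1 `CCCCCCCCC(CCO)n1cnc2c(NC)ncnc21` gives 3770 nM, compound 2 `CCCCCCCCC[C@H](CCOS(C)(=O)=O)n1cnc2c(Cl)ncnc21` gives 9720 nM and compound 3 `CCCCCCCCCC(CCOS(C)(=O)=O)n1cnc2c(Cl)ncnc21` gives 5390 nM. Compound 3 lies within the scatter of both other compounds. Compound 4 `CCCCCCCCCC(CCn1cc(-c2ccccc2)nn1)n1cnc2c(Cl)ncnc21` differs from compound 3 as follows: 4-phenyl-1H-1,2,3-triazol-1-yl in place of (methylsulfonyl)oxy on a saturated chain carbon, three bonds along the chain from an aromatic nitrogen. For the measured compounds named here, the one measured step, a 1.8-fold lower number from compound 2 to compound 3 (0.26 log units; within the scatter), goes with the fact that one of compounds 2 and 3 is drawn with a defined configuration and the other without, at the place where they differ and does not touch this group, so it gives no direct guide to the exchange. Going by the values given here, with no measured precedent for the change, no step beyond the scatter is expected in this assay. The estimated step is a 1.1-fold lower number from compound 3 to compound 4 (0.03 log units; within the scatter), and its direction is uncertain. For compound 4 the expected value is 5000 nM, with an estimated range of 1500 nM to 17000 nM.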

Compound 4, half-maximal inhibitory concentration: 9920 nM
Compound 4: middle estimate off by 2.0-fold (0.30 log units), on the low side, and the stated range covers the measured number.
By their numbers in this assay, from the lowest: compounds 1, 3, 2 and 4 (each within the scatter of the next, the first and the last beyond it).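

In this assay, 4-phenyl-1H-1,2,3-triazol-1-yl in place of (methylsulfonyl)oxy gives a 1.8-fold higher number from compound 3 to compound 4 (0.26 log units; within the scatter). For the compounds shown here, this place on the saturated chain therefore carries a group with two aromatic rings without a step beyond the scatter, something the earlier compounds, with no ring in the group there, did not show. Nothing measured bears on what lies behind this step.

Still open, going by these compounds, is whether an amine or a carboxylic acid at this place would give a step beyond the scatter. Also open, on these data alone, is how the triazole ring would read without its phenyl group.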